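The compounds below may be only part of what the source reports. "The series", "measured", "known", "first", "only" and "open" are said of these compounds alone.

For the measured compounds named here, in a functional assay on A549 cells (Homo sapiens) for cytotoxicity, read by MTT assay, with a stated time of 24 h (a lower number here means a stronger inhibitor, a higher number a weaker inhibitor), compound 2 `C=CC1=C(C(=O)Nc2ccc(OCC)cc2)C(c2ccc(OC)cc2)OC1` gives 17600 nM, the only full number among the three compounds measured so far. Compound 1 `C=CC1=C(C(=O)NC(C)(C)C)C(c2ccc(OC)cc2)OC1` reaches only a limit of the assay, > 100000 nM. Compound 3 `C=CC1=C(C(=O)NCc2ccc(Cl)cc2)C(c2ccc(OC)cc2)OC1` likewise stops at a limit, > 100000 nM. The step from compound 1 to compound 2 (an at least 5.6-fold lower number from compound 1 to compound 2 (0.75 log units; beyond the scatter)) and the step from compound 2 to compound 3 (an at least 5.6-fold higher number from compound 2 to compound 3 (0.75 log units; beyond the scatter)) both change the group on the amide-type nitrogen, while the step from compound 1 to compound 3 (a step that the two limits leave unreadable from compound 1 to compound 3) cannot be read. Compound 4 `C=CC1=C(C(=O)Nc2ccc(OCC)cc2)C(c2ccc(F)cc2)OC1` differs from compound 2 at a different place: fluoro in place of methoxy on an aromatic carbon. Going by the values given here, none of the measured steps touches this place, so none of them bears directly on the change, and the expectation rests on compound 2 alone, with a step expected to stay within the scatter, a 1.1-fold higher number from compound 2 to compound 4 (0.06 log units; within the scatter). Compound 4 is therefore estimated at 20000 nM in this assay, within a range of 7000 nM to 60000 nM.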

Compound 4, half-maximal inhibitory concentration: "not active" (no number reported)
No number was reported for compound 4; no gap can be computed for the estimate.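

Compound 4 is reported only as "not active", with no number, so no new step can be read between compound 2 and compound 4. The compounds shown leave open whether, and how far, fluoro in place of methoxy shifts the number in this assay, and whether compound 4 would sit at the same mark as two others: the limit of > 100000 nM in this assay, at which 2 of the 4 values shown sit.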